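A few compounds are considered here, and "the series" means these few. Any claim that something is new, unique, unknown or untested is made for them only; others in the source may bear on it.

Three compounds of the series have numbers in a functional assay on MGC-803 cells (Homo sapiens) for inhibition, read by MTT assay, with a stated time of 72 h; a higher number here means a weaker inhibitor, a lower number a stronger inhibitor. Compound 1 `Cc1cc(Nc2ccn(Cc3cccc4ccccc34)n2)n2nc(SCc3ccc(Br)cc3)nc2n1` gives 3240 nM. Compound 2 `Cc1cc(Nc2cc(-c3ccccc3)[nH]n2)n2ncnc2n1` gives 21700 nM, and compound 3 `Cc1cc(Nc2cc(-c3ccccc3)[nH]n2)n2nc(SCC3CC3)nc2n1` gives 16100 nM. Within the data shown here, the only single-point step measured so far is a 1.3-fold lower number from compound 2 to compound 3 (0.13 log units; within the scatter), a (cyclopropylmethyl)sulfanyl in place of hydrogen on an aromatic carbon, and it changes nothing beyond the scatter. Compound 1 stands at the lowest number of the three, and both gaps, to compound 3 and to compound 2, lie beyond the scatter; compound 1 differs from those two in more than one place, so no single cause can be drawn from that.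

Compound 4 `Cc1cc(Nc2ccn(Cc3ccccc3)n2)n2nc(SCc3ccc(Br)cc3)nc2n1` is the next entry. It differs from compound 1 by phenyl in place of naphthalen-1-yl on a saturated chain carbon bound to an aromatic nitrogen. Among the measured compounds shown here, no measured step in this assay touches the group on the saturated chain carbon bound to an aromatic nitrogen, so the step from compound 1 to compound 4 has no direct precedent here. For the measured compounds named here, the one measured step, at a different position, was within the scatter. With no guidance, the working expectation for compound 4 is a small loss, a 1.7-fold higher number from compound 1 to compound 4 (0.23 log units; within the scatter), and an estimated 5500 nM in this assay, ranging from 2500 nM to 13000 nM.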

Compound 4, half-maximal inhibitory concentration: 4720 nM
The estimate for compound 4 lay 1.2-fold (0.07 log units) above the measured number; low and high end bracket the measured number.
By their numbers in this assay, from the lowest: compounds 1 and 4 (each within the scatter of the next); then compounds 3 and 2 (each within the scatter of the next).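

In this assay, among these compounds, the step of a 1.5-fold higher number from compound 1 to compound 4 (0.16 log units; within the scatter) is the first reading at the saturated chain carbon bound to an aromatic nitrogen, and it stays within the scatter. On this core and with this sulfanyl group, (naphthalen-1-yl)methyl and benzyl are therefore not separated by this assay, although the change takes the group from 10 heavy atoms to 6 and from two six-membered aromatic rings of carbon only to one. This is a single pair, so it describes these two aromatic groups and sets no general rule for the position, and no measured evidence is available to explain the result.

On these data alone, it remains open whether a group of a different kind on this saturated chain carbon, such as an amine, a carboxylic acid or a longer alkyl chain, would move the number beyond the scatter. As far as these compounds go, compounds 1 and 4 also share the same sulfanyl group, so it is equally open whether the naphthalen-1-yl to phenyl change would read the same with another group at that place.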